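The compounds below may be only part of what the source reports. "The series", "measured", "known", "first", "only" and "open" are said of these compounds alone.

Working notes on the series. Of the compounds shown here, three have been measured in a functional assay for agonist activity at growth hormone secretagogue receptor type 1 (Homo sapiens), read by FLIPR; a lower number here means a smaller maximal response, a higher number a larger maximal response. Compound 1 `C[C@@H]1CN(c2cccc(NS(=O)(=O)c3ccc(-c4ccccn4)s3)c2)C[C@H](C)N1` gives 0.8, compound 2 `C[C@@H]1CN(c2ccc(F)c(NS(=O)(=O)c3ccc(-c4ccccn4)s3)c2)C[C@H](C)N1` gives 0.8, and compound 3 `COc1ccc(N2C[C@@H](C)N[C@@H](C)C2)cc1NS(=O)(=O)c1ccc(-c2ccncc2)cc1` gives 0.7. For the measured compounds named here, the one step between compounds that differ in one place, no change at the digits printed from compound 1 to compound 2 (within the scatter), changes nothing beyond the scatter. Compound 3 stands within the scatter of both compound 1 and compound 2, so no ordering among the three can be drawn.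

Compound 4 `COc1ccc(N2C[C@@H](C)N[C@@H](C)C2)cc1NS(=O)(=O)c1ccc(OCc2ccccc2)cc1` is not yet measured. It differs from compound 3 in one place: benzyloxy in place of pyridin-4-yl on an aromatic carbon. Going by the values given here, no measured step bears on this exchange; the only step on hand, no change at the digits printed from compound 1 to compound 2 (within the scatter), concerns a fluoro in place of hydrogen and leaves the maximal response unchanged. Among the compounds with values here, all three measured compounds, despite differing aryl groups on the sulfonamide, sit close together in this assay, and that is the only guide.

For compound 4 the expectation is a value near compound 3, with a wide range; compound 4 is expected to give 0.7, between 0.4 and 0.9, that is a step of no change at the digits printed from compound 3 to compound 4 (within the scatter).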

Compound 4, intrinsic activity: the largest response reached, as a fraction of the reference agonist's: 0.8
Compound 4: middle estimate off by 0.10, on the low side; low and high end bracket the measured number.
By their numbers in this assay, from the lowest: compounds 3, 1, 2 and 4 (each within the scatter of the next).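

Benzyloxy in place of pyridin-4-yl gives a number 0.10 higher from compound 3 to compound 4 (within the scatter) in this assay, so the read-out does not separate these two groups at this position, para to a large group. The exchange swaps a six-membered aromatic ring with 1 hetero atom for a larger group whose six-membered aromatic ring is of carbon only, and the maximal response of compound 4 stays within the scatter of that of compound 3. No measurement on hand gives a reason for this result.

Open, on these data alone, is whether the position keeps this maximal response with a group unlike these two, such as a carboxylic acid or a primary amine. Also open, as far as these compounds go, is whether a longer chain between the oxygen and the phenyl ring of benzyloxy would leave compound 4's response in this assay within the scatter.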